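Cyclopropyl in Place of 1-Methylethenyl on the Carbonyl

The compounds below may be only part of what the source reports. "The series", "measured", "known", "first", "only" and "open" are said of these compounds alone.

Compound 1 `C=C(C)C(=O)N(Cc1ccc(OC)c(O)c1)c1cc(OC)c(OC)c(OC)c1`: 200 nM
Compound 2 `COc1ccc(N(Cc2cc(OC)c(OC)c(OC)c2)C(=O)CCl)cc1O`: 22500 nM
Compound 3 `C/C=C/C(=O)N(Cc1cccc(O)c1)c1cc(OC)c(OC)c(OC)c1`: 6700 nM

All three were tested in a functional assay on HCT-116 cells (Homo sapiens) for inhibition, read by MTT assay, with a stated time of 48 h; on this read-out higher numbers stand for weaker inhibition and lower numbers for stronger inhibition. Compound 1 gives the lowest number of the three; compound 3 and compound 2 both lie above it, each beyond the usual scatter. Compound 4 `COc1ccc(CN(C(=O)C2CC2)c2cc(OC)c(OC)c(OC)c2)cc1O` is built from compound 1 with one change: cyclopropyl in place of 1-methylethenyl on a carbonyl carbon. Within the data shown here, no measured pair isolates this change. The two compounds without the 1-methylethenyl group, compound 2 and compound 3, give weaker numbers, though each also differs from compound 1 elsewhere, so they are only a rough guide. A weakening step is expected, a 15-fold higher number from compound 1 to compound 4 (1.18 log units; beyond the scatter), beyond the scatter. Compound 4 is estimated at 3000 nM, with a likely range from 500 nM to 20000 nM.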

Compound 4, half-maximal inhibitory concentration: 49 nM
Compound 4: the middle estimate sits 61-fold (1.79 log units) above what was measured; the measured number lies below the stated range.
By their numbers in this assay, from the lowest: compound 4; then compound 1; then compound 3; then compound 2.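

Moving from 1-methylethenyl to cyclopropyl on the carbonyl carbon, with the same three carbons now closed into a ring, gives a 4.1-fold lower number from compound 1 to compound 4 (0.61 log units; beyond the scatter) in this assay. The double bond of compound 1 is therefore not needed at this position, at least on this core, and a small carbon ring is accepted there. Nothing measured here explains the gain.

Going by these compounds, whether cyclobutyl, a larger carbon ring, or isopropyl, an open saturated group, would do as well on the same carbonyl stays open. So does whether cyclopropyl would bring the same gain on the cores of compound 2 and compound 3.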